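Compound 4: A Shorter Amino Chain

The compounds below may be only part of what the source reports. "The series", "measured", "known", "first", "only" and "open" are said of these compounds alone.

Compound 1 `C[C@@H](Nc1c(C(=O)NCc2ccc(F)cc2)nc(Br)c2cccnc12)c1ccccc1` reads "not determined" (no result reported)
Compound 2 `CN(C)CCCNc1c(C(=O)NCc2ccc(F)cc2)nc(Br)c2cccnc12` reads 7000 nM
Compound 3 `N[C@H]1CC[C@H](Nc2c(C(=O)NCc3ccc(F)cc3)nc(N3CCCCC3)c3cccnc23)CC1` reads 5000 nM

All three compounds were tested in a functional assay on MCF7 cells (Homo sapiens) for cytotoxicity, read by MTT assay, with a stated time of 72 h (on this read-out lower numbers stand for stronger inhibition and higher numbers for weaker inhibition), and share one core. Among the measured compounds shown here, compound 1 has no number to place, so only two values can be compared. Compound 2 (7000 nM) and compound 3 (5000 nM) lie within the usual scatter of each other, so neither can be ranked against the other.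

Compound 4 `NCCNc1c(C(=O)NCc2ccc(F)cc2)nc(Br)c2cccnc12` has not been measured yet. It differs from compound 2 in one place: amino in place of (dimethylamino)methyl on a saturated chain carbon, two bonds along the chain from a nitrogen on an aromatic ring. Read one bond further out, (3-(dimethylamino)propyl)amino becomes (2-aminoethyl)amino.

For the measured compounds named here, no measured pair shows a change of this kind, so the data give no direct guide to its size or direction. The starting point is therefore compound 2 (7000 nM), and no shift beyond the scatter is expected. The estimated step of a 1.4-fold lower number from compound 2 to compound 4 (0.15 log units; within the scatter) is accordingly a small one. Compound 4 is expected in this assay at 5000 nM (estimated range 1500 nM to 16000 nM).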

Compound 4, half-maximal inhibitory concentration: 6000 nM
Estimate against measurement, compound 4: 1.2-fold (0.08 log units) below; the range from low to high includes it.
By their numbers in this assay, from the lowest: compounds 3, 4 and 2 (each within the scatter of the next).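

In this assay, among the compounds shown here, the change from (3-(dimethylamino)propyl)amino to (2-aminoethyl)amino gives a 1.2-fold lower number from compound 2 to compound 4 (0.07 log units; within the scatter), the first step in this set between two compounds that differ in one place. On a saturated chain carbon, two bonds along the chain from a nitrogen on an aromatic ring, this read-out therefore does not separate the two chains, although the (dimethylamino)methyl that leaves has 4 heavy atoms and 0 hydrogen-bond donors, and the amino that enters has 1 heavy atom and 1 hydrogen-bond donor. No other measurement is available to explain this result.

For the compounds shown here, the single step changes the chain length and the groups on the end nitrogen together, so a 3-aminopropyl chain or a 2-(dimethylamino)ethyl chain would be needed to tell those two differences apart. Also open, as far as these compounds go, is how a chain ending in a hydroxyl group or a carboxylic acid, rather than an amine, would read at this position.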